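Swapping a Bulky Ester for a Hydroxybutyl Amide

This account rests on a few compounds, and the source may have more. Where it says the series, first, only, none or still open, it means among the compounds named here.

Of the compounds shown here, three built on one shared core have been tested in an assay on HEK293 cells for displacement of a labelled ligand from NPC1-like intracellular cholesterol transporter 1 (Homo sapiens); a lower number here means a stronger inhibitor, a higher number a weaker inhibitor. Compound 1 `O=C(CN1CN(c2ccccc2)C2(CCN(C(=O)c3ccc(C4CCCCC4)cc3)CC2)C1=O)NCCCCO` gives 10300 nM. Compound 2 `CCOC(=O)C1CCN(C(=O)CN2CN(c3ccccc3)C3(CCN(C(=O)c4ccc(C(C)(C)C)cc4)CC3)C2=O)CC1` gives 3100 nM, and compound 3 `CC1(C)CC(OC(=O)CN2CN(c3ccccc3)C3(CCN(C(=O)c4ccc(C(C)(C)C)cc4)CC3)C2=O)CC(C)(C)N1` gives 1300 nM. Compound 3 therefore stands lowest of the three numbers; the step of a 2.4-fold lower number from compound 2 to compound 3 (0.38 log units; beyond the scatter) separates it from its nearest neighbour, while compound 1 lies furthest away.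

Compound 4 `CC(C)(C)c1ccc(C(=O)N2CCC3(CC2)C(=O)N(CC(=O)NCCCCO)CN3c2ccccc2)cc1` has not yet been measured. It differs from compound 3 in one place: (4-hydroxybutyl)amino in place of (2,2,6,6-tetramethylpiperidin-4-yl)oxy on a carbonyl carbon. Going by the values given here, the same (4-hydroxybutyl)amino group on a carbonyl carbon is already present in compound 1, which gives a markedly higher number than either compound 2 or compound 3, although compound 1 also carries a different group elsewhere, so no single measured step isolates this change. Among the compounds with values here, the one measured step, from compound 2 to compound 3, concerns a different exchange at the same carbonyl carbon and was modest.

Because compound 1 gives 10300 nM while carrying this group, compound 4 is expected to move toward a weaker number, a step of a 4.6-fold higher number from compound 3 to compound 4 (0.66 log units; beyond the scatter). Compound 4 is thus estimated at 6000 nM, with a range from 2000 nM to 18000 nM.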

Compound 4, half-maximal inhibitory concentration: 19200 nM
Estimate against measurement, compound 4: 3.2-fold (0.51 log units) below; the measured number lies above the stated range.
By their numbers in this assay, from the lowest: compound 3; then compound 2; then compounds 1 and 4 (each within the scatter of the next).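

In this assay, the exchange of (2,2,6,6-tetramethylpiperidin-4-yl)oxy for (4-hydroxybutyl)amino on this carbonyl carbon gives a 15-fold higher number from compound 3 to compound 4 (1.17 log units; beyond the scatter) and is a large step, showing that this position does respond strongly to the group placed there. The exchange of 4-(ethoxycarbonyl)piperidin-1-yl for the same (4-hydroxybutyl)amino group gives the smaller 6.2-fold higher number from compound 2 to compound 4 (0.79 log units; beyond the scatter) in the same direction, and with (4-hydroxybutyl)amino in place, tert-butyl in place of cyclohexyl on the aromatic carbon gives a 1.9-fold higher number from compound 1 to compound 4 (0.27 log units; within the scatter) and so leaves the two compounds level. Nothing measured here explains why the exchange at the carbonyl carbon has such a large effect.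

These compounds leave open whether the large step follows the change of linking atom, the loss of the ring or the chain itself, and a (2,2,6,6-tetramethylpiperidin-4-yl)amino group or a 4-hydroxybutoxy group on the same carbonyl carbon would help to separate these. Also open, from the compounds shown here alone, is whether tert-butyl and cyclohexyl would remain level with (2,2,6,6-tetramethylpiperidin-4-yl)oxy on that carbon.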